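A few compounds are considered here, and "the series" means these few. Any claim that something is new, unique, unknown or untested is made for them only; others in the source may bear on it.

Measured so far:
compound 1 `CNCC(=O)OCOC(=O)N1CCN(c2cc3c(cc2F)c(=O)c(C(=O)O)cn3C2CC2)CC1`: 0.35 h
compound 2 `CNCC(=O)OC(C)OC(=O)N1CCN(c2cc3c(cc2F)c(=O)c(C(=O)O)cn3C2CC2)CC1`: 1.6 h
compound 3 `CN[C@H](C(=O)OC(C)OC(=O)N1CCN(c2cc3c(cc2F)c(=O)c(C(=O)O)cn3C2CC2)CC1)C(C)C`: 2.4 h

In a physicochemical assay for pharmacokinetics, read by HPLC, at pH 7.5 (on this read-out lower numbers stand for a shorter-lived compound and higher numbers for a longer-lived compound), compound 3 gives the highest number of the three measured; its step to compound 2 is within the scatter, its step to compound 1 beyond it. Compound 4 `CC(OC(=O)[C@H](C)NC(=O)c1ccccc1)OC(=O)N1CCN(c2cc3c(cc2F)c(=O)c(C(=O)O)cn3C2CC2)CC1` carries 1-benzamidoethyl in place of 2-methyl-1-(methylamino)propyl on a carbonyl carbon. Going by the values given here, of the measured steps, only the one on the carbon bound to an amine nitrogen and a carbonyl carbon bears on this change: a 1.5-fold higher number from compound 2 to compound 3 (0.18 log units; within the scatter). That step was within the scatter. On these data alone, the change from a 2-methyl-1-(methylamino)propyl group to a 1-benzamidoethyl group is untested here, so no direction can be read from the series. Compound 4 is therefore expected to stand near compound 3, with a 1.3-fold higher number from compound 3 to compound 4 (0.10 log units; within the scatter) as the estimated step. The estimate for compound 4 in this assay is 3 h, range 1.2 h to 7.5 h.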

Compound 4, half-life: > 60 h
Compound 4 was reported as a limit; the forecaster's own chance of this, stated with the estimate: 5%; middle value at least 20-fold (1.30 log units) from the limit.
By their numbers in this assay, from the lowest: compound 1; then compounds 2 and 3 (each within the scatter of the next). At a limit, above all of these: compound 4.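

In this assay compound 4 gives > 60 h, a limit of the assay and not a number. On a carbonyl carbon whose other neighbours are oxygen next to a carbonyl group, the earlier change gave only a 1.5-fold higher number from compound 2 to compound 3 (0.18 log units; within the scatter), whereas 1-benzamidoethyl in place of 2-methyl-1-(methylamino)propyl gives an at least 25-fold higher number from compound 3 to compound 4 (1.39 log units; beyond the scatter). In place of (methylamino)methyl, the same group gives an at least 37-fold higher number from compound 2 to compound 4 (1.57 log units; beyond the scatter), so this position can carry large steps.

The benzamido amide and the aromatic ring enter together, leaving their separate shares open. A 1-acetamidoethyl group or a 1-aminoethyl group at this position would separate them.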